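A Methyl Added to the Phenylethynyl Arm of Compound 3

A few compounds are considered here, and "the series" means these few. Any claim that something is new, unique, unknown or untested is made for them only; others in the source may bear on it.

Compound 3 `CN1CCC[C@H]1COc1cncc(C#Cc2ccccc2)c1` carries a phenyl joined through an ethyne to the shared core. In an assay on membranes from brain for binding affinity to Neuronal acetylcholine receptor; alpha4/beta2 (Rattus norvegicus) (a lower number here means a stronger inhibitor, a higher number a weaker inhibitor), compound 3 gives 0.16 nM. Compound 1 `CN1CCC[C@H]1COc1cncc(-c2ccccc2)c1` gives 0.11 nM in this assay, and compound 2 `CN1CCC[C@H]1COc1cncc(-c2cc3ccccc3n2C)c1` gives 0.32 nM; all three numbers lie within the scatter of one another, so no order among them can be read. Compound 4 `Cc1ccc(C#Cc2cncc(OC[C@@H]3CCCN3C)c2)cc1` differs from compound 3 by methyl in place of hydrogen on an aromatic carbon. Among the compounds with values here, no step between measured compounds resembles this change, and the three values already sit close together. The step of a 1.6-fold higher number from compound 3 to compound 4 (0.19 log units; within the scatter) is therefore expected to stay within the scatter, with no clear direction. Compound 4 is estimated at 0.25 nM, with a range from 0.08 nM to 0.8 nM.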

Compound 4, inhibition constant: 0.31 nM
The estimate for compound 4 lay 1.2-fold (0.09 log units) below the measured number; low and high end bracket the measured number.
By their numbers in this assay, from the lowest: compounds 1, 3, 4 and 2 (each within the scatter of the next, the first and the last beyond it).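

In this assay, within the data shown here, the exchange of hydrogen for methyl on the aromatic carbon gives a 1.9-fold higher number from compound 3 to compound 4 (0.29 log units; within the scatter) and is the first single-place step available. It shows that phenyl to 4-methylphenyl, at this place para to a large group, brings no difference that can be read from the repeat scatter. Nothing measured here explains this result.

A single methyl does not settle how this place responds to other groups. As far as these compounds go, whether an amine, a carboxylic acid or a longer chain there would stay within the scatter of compound 3 remains open.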